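The source may hold more compounds than are shown below. What is called first, only, known or untested is meant among the compounds shown, and "the series" means these compounds.

Working notes on the amide series built on the shared core of compound 1.

For the measured compounds named here, compound 1 `CCN(CC)CCCOc1cc2ncnc(Nc3nc4ccc(C(=O)Nc5c(C)cccc5C)cc4s3)c2cc1OC` gives 66500 nM in a functional assay on NCI-H661 cells (Homo sapiens) for cytotoxicity, read by WST assay, with a stated time of 72 h (on this read-out higher numbers stand for weaker inhibition and lower numbers for stronger inhibition), the highest number among the three compounds measured so far. Going by the values given here, compound 3 `CCN(CC)CCCOc1cc2ncnc(Nc3nc4ccc(C(=O)Nc5c(C)cccc5Cl)cc4s3)c2cc1OC` gives 11200 nM in this assay; the only single-point step recorded, a 5.9-fold lower number from compound 1 to compound 3 (0.77 log units; beyond the scatter), concerns chloro in place of methyl on an aromatic carbon and does not touch the amine end of the chain. Compound 2 `COc1cc2c(Nc3nc4ccc(C(=O)Nc5c(C)cc(C)cc5C)cc4s3)ncnc2cc1OCCCN1CCCCC1C` gives 8800 nM in this assay, but it differs from compound 1 in more than one place, so its lower number cannot be assigned to any one change.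

Compound 4 `COc1cc2c(Nc3nc4ccc(C(=O)Nc5c(C)cccc5C)cc4s3)ncnc2cc1OCCCN1CCC(C)CC1` is the next step from compound 1: 4-methylpiperidin-1-yl in place of diethylamino on a saturated chain carbon, three bonds along the chain from an oxygen on an aromatic ring. Among the compounds with values here, no measured step bears directly on this change; the only hint is the lower number of compound 2, which also carries a ring amine but is confounded. The step is therefore expected to be small or moderate, with a lower number somewhat more likely than a higher one, estimated as a 1.9-fold lower number from compound 1 to compound 4 (0.28 log units; within the scatter). Compound 4 is expected to give about 35000 nM in this assay, within a range of 10000 nM to 110000 nM.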

Compound 4, half-maximal inhibitory concentration: 72300 nM
Compound 4: middle estimate off by 2.1-fold (0.32 log units), on the low side; the range from low to high includes it.
By their numbers in this assay, from the lowest: compounds 2 and 3 (each within the scatter of the next); then compounds 1 and 4 (each within the scatter of the next).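

For the compounds shown here, with the rest of compound 1 held fixed, 4-methylpiperidin-1-yl in place of diethylamino gives a 1.1-fold higher number from compound 1 to compound 4 (0.04 log units; within the scatter) in this assay and so provides the first direct reading at the amine end of the chain. In this pair, the ring amine and the open-chain amine cannot be told apart, even with the larger group and the added six-membered ring. No available measurement explains this result.

Going by these compounds alone, only this one ring amine has been read against diethylamino on an otherwise unchanged compound, so it remains open whether pyrrolidin-1-yl, morpholin-4-yl or a longer chain would also leave the number within the scatter. Going by these compounds, it also remains open whether this exchange would read the same on the chloro-bearing amide of compound 3.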